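Nitro for Bromo on Two Related Cores

The compounds below may be only part of what the source reports. "The series", "measured", "known", "first", "only" and "open" are said of these compounds alone.

Of the compounds shown here, three have been tested in a functional assay on the whole organism with Mus musculus as the target, in the rotarod test; on this read-out lower numbers stand for an effect already at smaller amounts and higher numbers for an effect only at larger amounts of compound. Compound 3 `COc1cc2c(cc1OC)C(c1ccc(Br)cc1)=NN=C(S)C2` gives 73 umol/kg. Compound 2 `COc1cc2c(cc1OC)C(c1ccc(Br)cc1)=NNC(=O)C2` gives 226 umol/kg, the highest of the two numbers, with compound 3 standing nearest at a lower number. How the cores of compound 2 and compound 3 differ is not broken down here. Compound 1 `COc1cc2c(cc1OC)C(c1ccc([N+](=O)[O-])cc1)=NN=C(S)C2` reaches only a limit of this assay, > 150 umol/kg. The change from compound 3 to compound 1 is nitro in place of bromo on an aromatic carbon, and it gives an at least 2.0-fold higher number from compound 3 to compound 1 (0.31 log units; beyond the scatter); one of the three values sits at the limit of > 150 umol/kg in this assay, at which 1 of the 3 values shown sits, so this step is known only as a lower bound.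

Compound 4 `COc1cc2c(cc1OC)C(c1ccc([N+](=O)[O-])cc1)=NNC(=O)C2` has not yet been measured. It arises from compound 2 by nitro in place of bromo on an aromatic carbon, the same change with the same surroundings as between compound 3 and compound 1. The step is expected to be a 2.4-fold higher number from compound 2 to compound 4 (0.39 log units; beyond the scatter), resting on an at least 2.0-fold higher number from compound 3 to compound 1 (0.31 log units; beyond the scatter). Compound 4 is therefore expected to give 550 umol/kg, most likely between 250 umol/kg and 1500 umol/kg, with a fair chance that only a limit is reported.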

Compound 4, dose for half-maximal effect: > 150 umol/kg
Compound 4: only a limit was reported; the forecaster's own chance of this, stated with the estimate: 50%; the middle value is on the limit's open side.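

In this assay, among these compounds, compound 4 gives > 150 umol/kg, which is a limit, so no step from compound 2 to compound 4 can be read. The compounds shown leave open how large the change of nitro in place of bromo is on either core, and whether it matches between them, with compound 1 and compound 4 both at one limit: the limit of > 150 umol/kg in this assay, at which 2 of the 4 values shown sit.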